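The source may hold more compounds than are shown below. What is called first, only, known or untested is meant among the compounds shown, and "the series" means these compounds.

Compound 1 `Cc1cc(O)c(C2=NN(c3ccc(S(N)(=O)=O)cc3)C(c3ccccc3O)C2)cc1Cl` gives 37100 nM in a functional assay on SNB-75 cells (Homo sapiens) for antiproliferative activity, with a stated time of 48 h; a higher number here means that more compound is tolerated, a lower number that less compound is tolerated.
Compound 2 `Cc1cc(O)c(C2=NN(c3ccc(S(N)(=O)=O)cc3)C(/C=C/c3ccccc3)C2)cc1Cl` gives 44400 nM in this assay.

Within the data shown here, only two compounds have been measured, and their numbers lie within the scatter of each other: the step of a 1.2-fold higher number from compound 1 to compound 2 (0.08 log units; within the scatter) is the sole comparison available, and it shows that exchanging the group on the saturated ring carbon left the read-out essentially unchanged. Compound 3 `COc1ccc(C2CC(c3cc(Cl)c(C)cc3O)=NN2c2ccc(S(N)(=O)=O)cc2)cc1OC` carries a further exchange at the same place: 3,4-dimethoxyphenyl in place of 2-phenylethenyl on a saturated ring carbon. Among the measured compounds shown here, the one measured step that bears on this position is the exchange from compound 1 to compound 2, and it was within the scatter, so another aryl group on that carbon is expected to move the number in this assay by no more than the scatter, in no particular direction. The expected step of a 1.1-fold lower number from compound 2 to compound 3 (0.05 log units; within the scatter) is therefore small. Compound 3 is estimated at 40000 nM in this assay, with a range from 20000 nM to 80000 nM.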

Compound 3, concentration lethal to 50% of the cells: > 100000 nM
Compound 3 was reported as a limit; the forecaster's own chance of this, stated with the estimate: 15%; middle value at least 2.5-fold (0.39 log units) from the limit.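

The reading for compound 3 in this assay is a limit of the assay and not a number: the limit of > 100000 nM in this assay, at which 1 of the 3 values shown sits.

Even so, the 3,4-dimethoxyphenyl group on the saturated ring carbon gives an at least 2.2-fold higher number from compound 2 to compound 3 (0.35 log units; beyond the scatter) and an at least 2.6-fold higher number from compound 1 to compound 3 (0.43 log units; beyond the scatter), both beyond the scatter, whereas the only earlier exchange at this carbon stayed within it. This position can therefore change how much compound is tolerated, and the exchange of 2-phenylethenyl or 2-hydroxyphenyl for 3,4-dimethoxyphenyl is the first change shown to do so, with its full size unknown.

The compounds shown leave open whether both methoxy groups are needed for this step, or whether a single methoxy group on the phenyl ring would give it too. They also leave open what an amine or a carboxylic acid on that phenyl ring would do to the read-out.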